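The source may report more compounds than this note shows. Statements on the series, on what has been measured and on what is new or still open speak of the compounds shown alone.

Compound 1 `COc1ccccc1N1CCN(C[C@@H](O)COc2ccc(Cl)cc2)CC1` — 47.4%
Compound 2 `O[C@@H](COc1ccc(F)cc1)CN1CCN(c2ccc(F)cc2)CC1` — 47.5%
Compound 3 `O[C@H](COc1ccc(Cl)cc1)CN1CCN(c2ccc(F)cc2)CC1` — 28.3%

Of the compounds shown here, three have been tested in an assay on HEK293 cells for inhibition of Voltage-dependent T-type calcium channel subunit alpha-1G (Homo sapiens), read by patch clamp, tested at 10 uM; on this read-out higher numbers stand for more inhibition at the one concentration tested (going by the name of the read-out) and lower numbers for less inhibition. Compound 1 gives 47.4% and compound 2 gives 47.5%; these two numbers lie within the usual scatter of each other. Compound 3 gives 28.3%, the lowest of the three, and it sits beyond the scatter below both compound 1 and compound 2. For the measured compounds named here, no pair of the measured compounds differs in one place only, so no single change has yet been tied to a step in this assay.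

Compound 4 `O[C@@H](COc1ccc(Cl)cc1)CN1CCN(c2ccc(F)cc2)CC1` has not been measured. The difference from compound 3 is the two compounds have the same atoms and bonds and differ only in configuration as drawn: 1 of 1 stereo elements differ; a stereocentre at a saturated chain carbon is drawn S in compound 3 and R in compound 4. Going by the values given here, because compound 1 gives 47.4% and compound 2 gives 47.5%, both well above compound 3, there is room for the single remaining change to move the number upward, but nothing measured tells how large a step a change in configuration alone produces here. The step from compound 3 to compound 4 is therefore expected to be modest and positive, a number 13.7 percentage points higher from compound 3 to compound 4 (beyond the scatter). Compound 4 is estimated to give about 42%, with a range from 25% to 58%.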

Compound 4, a percentage reported as inhibition, at one concentration (the size of the read-out at that concentration, not a potency): 39.7%
Compound 4: the middle estimate sits 2.3 percentage points above what was measured; low and high end bracket the measured number.
By their numbers in this assay, from the lowest: compound 3; then compounds 4, 1 and 2 (each within the scatter of the next).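

In this assay, configuration at the stereocentre on the saturated chain carbon matters: going from S to R gives a number 11.4 percentage points higher from compound 3 to compound 4 (beyond the scatter), and this step can be tied to that stereocentre alone because nothing else in the structures changes: the fact that compounds 3 and 4 differ only in the configuration as drawn

Two other single changes do not stand out from the usual scatter: chloro in place of fluoro on an aromatic carbon gives a number 7.8 percentage points lower from compound 2 to compound 4 (within the scatter). Likewise, 4-fluorophenyl in place of 2-methoxyphenyl on an amine nitrogen in a ring gives a number 7.7 percentage points lower from compound 1 to compound 4 (within the scatter).

As far as these compounds go, it remains open whether the same switch in configuration would produce a similar step with the fluoro group of compound 2 or the 2-methoxyphenyl group of compound 1. Also open, from the compounds shown here alone, is how a bromo group in place of the chloro, or an amine in place of the hydroxyl, would read out.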